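This account rests on a few compounds, and the source may have more. Where it says the series, first, only, none or still open, it means among the compounds named here.

Measured in a functional assay on the whole organism (strain Wistar) for inhibition, with Rattus norvegicus as the target, with stated times of 30 min and 2 h, at a dose of 20 mg/kg by the oral route; a lower number here means less inhibition, a higher number more inhibition at the dose given (going by the name of the read-out):
Compound 1 `O=C(CCc1nnc(-c2ccccc2Cl)o1)c1ccccc1` — 26.9%
Compound 2 `Cc1ccc(C(=O)CCc2nnc(-c3ccccc3Cl)o2)cc1` — 36.2%

Compound 2 sits alongside compound 1, the step of a number 9.3 percentage points higher from compound 1 to compound 2 (within the scatter) lying within the scatter, so the two read as one level. Compound 3 `COc1ccc(-c2nnc(CCC(=O)c3ccc(C)cc3)o2)cc1` differs from compound 2 by 4-methoxyphenyl in place of 2-chlorophenyl on an aromatic carbon. Within the data shown here, no measured step touches this exchange; the only step known concerns a methyl elsewhere. With nothing pointing either way, compound 3 is expected to stay near compound 2, a step of a number 1.2 percentage points lower from compound 2 to compound 3 (within the scatter) that amounts to none beyond the scatter. Compound 3 is therefore estimated at 35%, with a range from 18% to 52%.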

Compound 3, a percentage reported as inhibition, in the whole organism at one dose (the size of the read-out at that dose, not a potency): 69.3%
Compound 3: the middle estimate sits 34.3 percentage points below what was measured; the measured number lies above the stated range.
By their numbers in this assay, from the lowest: compounds 1 and 2 (each within the scatter of the next); then compound 3.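

In this assay, this position on the five-membered aromatic ring responds strongly: 4-methoxyphenyl in place of 2-chlorophenyl gives a number 33.1 percentage points higher from compound 2 to compound 3 (beyond the scatter). The methyl exchange elsewhere in the molecule had stayed within the scatter, so this is the first change shown to move the read-out. Nothing at hand explains the step. The compounds shown leave open whether the gain comes from gaining the 4-methoxyphenyl or from losing the 2-chlorophenyl. On these data alone, it also remains open whether a plain phenyl or a pyridine ring here would reach the level of compound 3.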